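Benzyl Ester in Place of Methyl Ester on Two Cores

A few compounds are considered here, and "the series" means these few. Any claim that something is new, unique, unknown or untested is made for them only; others in the source may bear on it.

Compound 1 `C=C1C[C@]23C[C@@]1(O)CC[C@H]2[C@@]12C=C[C@H](O)[C@](C)(C(=O)O1)[C@H]2[C@@H]3C(=O)OC` and compound 2 `C=C1C[C@]23C[C@@]1(O)CC[C@H]2[C@@]12C=C[C@H](O)[C@](C)(C(=O)O1)[C@H]2[C@@H]3C(=O)OCc1ccccc1` share one core and differ only in the ester, the change being (phenyl in place of hydrogen on a saturated chain carbon bound to an oxygen next to a carbonyl group). In a functional assay on HL-60 cells (Homo sapiens) for cytotoxicity, read by MTT assay (a lower number here means a stronger inhibitor, a higher number a weaker inhibitor), compound 1 gives > 100 ug/mL, which is a limit of the assay and not a number. In this assay compound 2 gives > 100 ug/mL, again a limit rather than a number. The step that the two limits leave unreadable from compound 1 to compound 2 therefore cannot be sized, because of the limit of > 100 ug/mL in this assay, at which 2 of the 3 values shown sit.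

Compound 3 `C=C1C(=O)[C@]23C[C@@]1(Cl)CC[C@H]2[C@@]12C=CC(=O)[C@](C)(C(=O)O1)[C@H]2[C@@H]3C(=O)OC` rests on a different core; how the two cores differ is not broken down here. In this assay, within the data shown here, compound 3 gives 6.5 ug/mL, the only plain number among the three measured compounds. Compound 4 `C=C1C(=O)[C@]23C[C@@]1(Cl)CC[C@H]2[C@@]12C=CC(=O)[C@](C)(C(=O)O1)[C@H]2[C@@H]3C(=O)OCc1ccccc1` is compound 3 carrying the same change, (phenyl in place of hydrogen on a saturated chain carbon bound to an oxygen next to a carbonyl group), at the same place.

Among the measured compounds shown here, since the one earlier instance of this change leaves no readable step, the expectation for compound 4 leans on compound 3 alone, whose value 6.5 ug/mL sets the anchor. The expected step of a 1.2-fold higher number from compound 3 to compound 4 (0.09 log units; within the scatter) is small. Compound 4 is estimated to give 8 ug/mL, within 2.5 ug/mL to 25 ug/mL.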

Compound 4, half-maximal inhibitory concentration: 2.7 ug/mL
For compound 4 the middle estimate is 3.0-fold (0.47 log units) above the measured one; the range from low to high includes it.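

In this assay, replacing methoxycarbonyl with benzyloxycarbonyl on the core of compound 3 gives a 2.4-fold lower number from compound 3 to compound 4 (0.38 log units; beyond the scatter), so on this core the change brings a modest gain rather than a loss. The same change on the core of compound 1 cannot be set beside this step, because compound 1 and compound 2 both rest at a limit of the assay and not at a number: the limit of > 100 ug/mL in this assay, at which 2 of the 4 values shown sit. This leaves a single readable pair, which shows what the change does on one core but not whether the step carries over to the other.

The compounds shown leave open whether the gain needs the phenyl ring, or whether an ethyl ester, an ester with a longer chain or a free carboxylic acid in the same place would give a similar number. They also leave open which of the several differences between the two cores matters for the values seen here.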